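Chloromethylbenzyl purines: removing the amino group of compound 1

The source may hold more compounds than are shown below. What is called first, only, known or untested is meant among the compounds shown, and "the series" means these compounds.

Measured so far in a functional assay on U-251 cells (Homo sapiens) for cytotoxicity, read by sulforhodamine B assay, with a stated time of 48 h; a higher number here means a weaker inhibitor of growth, a lower number a stronger inhibitor of growth:
- compound 1 `Nc1nc(Cl)c2ncn(Cc3ccccc3CCl)c2n1`, compound 1 gives 13500 nM
- compound 2 `ClCc1ccccc1Cn1cnc2nc(Cl)nc(Cl)c21`, compound 2 gives 1170 nM
- compound 3 `ClCc1ccc(Cn2cnc3c(Cl)nc(Cl)nc32)cc1`, compound 3 gives 3890 nM

Compound 1 stands at the highest number of the three, so it is the weakest inhibitor of growth here. Its nearest neighbour on the numbers is compound 3, which sits beyond the scatter at a lower value; compound 2 lies furthest away, also beyond the scatter, at the lowest number of the set. Both compound 2 and compound 3 carry two chloro groups on the shared core and no amino, while compound 1 carries one chloro and the amino.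

Compound 4 `ClCc1ccccc1Cn1cnc2c(Cl)ncnc21` is not yet measured. It differs from compound 1 in one place: hydrogen in place of amino on an aromatic carbon. Within the data shown here, no step between measured compounds mirrors this change, so the direction is read only from the whole set, in which the two amino-free compounds show the lower numbers. A moderate move toward a lower number is expected for the step of a 2.3-fold lower number from compound 1 to compound 4 (0.35 log units; beyond the scatter), though nothing beyond the scatter can be ruled out. For compound 4 the estimate in this assay is 6000 nM, with a range from 2000 nM to 20000 nM.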

Compound 4, concentration for total growth inhibition: 6160 nM
The estimate for compound 4 lay 1.0-fold (0.01 log units) below the measured number; the range from low to high includes it.
By their numbers in this assay, from the lowest: compound 2; then compounds 3 and 4 (each within the scatter of the next); then compound 1.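

In this assay, among these compounds, the series shows a 2.2-fold lower number from compound 1 to compound 4 (0.34 log units; beyond the scatter), the first reading of a change at this one position, on an aromatic carbon between two ring nitrogen atoms. Hydrogen in place of amino gives a modest step beyond the scatter, so for this pair the amino group is not required for growth inhibition and its loss gives a stronger inhibitor. The earlier compounds offered no such single-place comparison, and no measurement shown accounts for the size or direction of this step.

Whether the step reflects the loss of the amino group's hydrogens or its mere presence stays open, since a methylamino, dimethylamino or methoxy group at this position is not among the compounds shown. From the compounds shown here alone, whether the step carries over to a chloro-bearing core, or to a different placement of the chloromethyl group, also stays open.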